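The source may hold more compounds than are shown below. What is called first, only, known or untested is meant among the compounds shown, and "the series" means these compounds.

Measured in a functional assay on A549 cells (Homo sapiens) for inhibition, read by MTT assay, with a stated time of 48 h; a higher number here means a weaker inhibitor, a lower number a stronger inhibitor:
- Compound 1 `Cc1ccc(NC(=O)Nc2cccc(-c3cccc4[nH]nc(N)c34)c2)cc1Cl`: 1750 nM
- Compound 2 `Nc1n[nH]c2cccc(-c3cccc(NC(=O)Nc4ccc(Cl)cc4Cl)c3)c12`: > 500000 nM

Compound 2 gives > 500000 nM, which is a limit of the assay and not a number. Compound 3 `CC(C)c1cccc(NC(=O)Nc2cccc(-c3cccc4[nH]nc(N)c34)c2)c1` has 3-isopropylphenyl in place of 2,4-dichlorophenyl on an amide-type nitrogen. For the measured compounds named here, one measured step bears on this, at the same place: an at least 280-fold higher number from compound 1 to compound 2 (2.45 log units; beyond the scatter). This single large step shows that the group here can matter greatly in this assay. A large move toward a stronger number is therefore expected, with compound 1 at 1750 nM as the guide. The expected change is an at least 83-fold lower number from compound 2 to compound 3 (1.92 log units; beyond the scatter). For compound 3 the estimated value is 6000 nM, with a range of 1000 nM to 60000 nM.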

Compound 3, half-maximal inhibitory concentration: 1420 nM
Estimate against measurement, compound 3: 4.2-fold (0.63 log units) above; measured number inside the range.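

In this assay, 3-isopropylphenyl on the amide-type nitrogen gives an at least 350-fold lower number from compound 2 to compound 3 (2.54 log units; beyond the scatter), and in place of 3-chloro-4-methylphenyl it gives a 1.2-fold lower number from compound 1 to compound 3 (0.09 log units; within the scatter). So two different substituted phenyl groups at this place give values within the scatter of each other, and among the three compounds only 2,4-dichlorophenyl stands apart. Compound 2 sits at a limit of the assay, not at a number: the limit of > 500000 nM in this assay, at which 1 of the 3 values shown sits.

Going by these compounds, whether an amine, a carboxylic acid or a longer chain at this place would hold the value of compound 3 remains open. On these data alone, the true size of the step to compound 2 also remains open.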